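The source may report more compounds than this note shows. Statements on the series, on what has been measured and on what is new or still open speak of the compounds shown alone.

Compound 1 `CN(CC1CCC/C(=C\c2ccccc2)C1=O)c1ccccc1` is the reference point of this small set. In a functional assay on the whole organism (Ear, strain Kunming) for inhibition, with Mus musculus as the target, with stated times of 1 h and 30 min, at a dose of 200 mg/kg by the oral route (on this read-out lower numbers stand for less inhibition and higher numbers for more inhibition at the one dose given (going by the name of the read-out)), compound 1 gives 49.7%. Compound 2 `Cc1cccc(N(C)CC2CCC/C(=C\c3ccccc3)C2=O)c1` carries a single change relative to compound 1, namely (methyl in place of hydrogen on an aromatic carbon); in this assay compound 2 gives 44.9%, and the step of a number 4.8 percentage points lower from compound 1 to compound 2 (within the scatter). Compound 3 `CN(CC1CCC/C(=C\c2ccc(S(C)(=O)=O)cc2)C1=O)c1ccccc1` is built on a different core, and the difference between the two cores is methylsulfonyl in place of hydrogen on an aromatic carbon; in this assay compound 3 gives 46.9%, and the step of a number 2.8 percentage points lower from compound 1 to compound 3 (within the scatter). The values of compound 2 and compound 3 lie within the scatter of each other, so no order among the three is claimed.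

Compound 4 `Cc1ccc(N(C)CC2CCC/C(=C\c3ccc(S(C)(=O)=O)cc3)C2=O)cc1` has not been measured. It differs from compound 3 by methyl in place of hydrogen on an aromatic carbon. This is the same kind of change as that from compound 1 to compound 2, but not the same: in compound 2 the methyl sits meta to a large group, in compound 4 it sits para to a large group, and the core of compound 4 carries the methylsulfonyl that compound 2 lacks. Within the data shown here, only one earlier instance of the change exists, and it left the value within the scatter. On that basis the step from compound 3 to compound 4 in this assay is expected to be small, about a number 3.9 percentage points lower from compound 3 to compound 4 (within the scatter), resting on the step of a number 4.8 percentage points lower from compound 1 to compound 2 (within the scatter). Compound 4 is therefore estimated at 43%, with a range from 32% to 54%.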

Compound 4, a percentage reported as inhibition, in the whole organism at one dose (the size of the read-out at that dose, not a potency): 27%
The estimate for compound 4 lay 16 percentage points above the measured number, outside the stated range (below it).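

In this assay the step is a number 19.9 percentage points lower from compound 3 to compound 4 (beyond the scatter), so the methyl change cannot be carried from one core to the other at a fixed size: the same change on two cores in this assay, a number 4.8 percentage points lower (within the scatter) from compound 1 to compound 2 and a number 19.9 percentage points lower (beyond the scatter) from compound 3 to compound 4, 15.1 percentage points apart, beyond the scatter of two such steps

This comparison does not show what sets the two steps apart, since two things differ at once: in compound 4 the methyl sits para to a large group, at a different place from the methyl of compound 2, and only the core of compound 4 carries the methylsulfonyl. With two instances, each read at a single dose, the series gives no rule for this change and no measure of potency, and the step within the scatter for compound 2 fixes no direction for the change on the core of compound 1.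

The compounds shown leave open whether the methyl at either place gives the same step on each core, which would separate the place of the methyl from the presence of the methylsulfonyl. They also leave open whether a chlorine, a methoxy group or a longer chain such as ethyl at that place would go with a step like that to compound 4, and whether a sulfonamide or a nitrile in place of the methylsulfonyl would alter it.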